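The compounds below may be only part of what the source reports. "The series", "measured", "known", "first", "only" and "open" are said of these compounds alone.

Measured in a functional assay on RAW264.7 cells (Mus musculus) for inhibition, read by fluorescence, with stated times of 1 h, 24 h and 30 min; on this read-out lower numbers stand for stronger inhibition and higher numbers for weaker inhibition:
Compound 1 `O=C(/C=C/c1ccc(C(F)(F)F)cc1)c1ccccc1O` gives only a limit (> 10000 nM).
Compound 2 `O=C(/C=C/c1ccc(C(F)(F)F)cc1)c1cccc(O)c1` gives only a limit (> 10000 nM).
Compound 3 `O=C(/C=C/c1ccc(C(F)(F)F)cc1)c1ccc(O)cc1` gives only a limit (> 10000 nM).

Among the measured compounds shown here, compound 2 therefore has no number to its name, and it stands with the other two compounds measured so far (the limit of > 10000 nM in this assay, at which 3 of the 3 values shown sit). Compound 4 `O=C(/C=C/c1ccc(OC(F)(F)F)cc1)c1cccc(O)c1` carries trifluoromethoxy in place of trifluoromethyl on an aromatic carbon, para to a large group (trifluoromethoxy in place of trifluoromethyl on an aromatic carbon).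

Three measured steps are available: a step that the two limits leave unreadable from compound 1 to compound 2 and a step that the two limits leave unreadable from compound 1 to compound 3 and a step that the two limits leave unreadable from compound 2 to compound 3 are the whole record. None has a readable size, and all of them change the hydroxyphenyl group on the carbonyl carbon rather than the group exchanged here, so they bear on this change only weakly.

With no size to carry over, no step beyond the scatter is expected in this assay in either direction, and the expected step is a number no higher from compound 2 to compound 4 (the limit leaves the size open) on this reckoning. The estimate for compound 4 is 10000 nM with an expected range from 3000 nM to 30000 nM and a report of only a limit is likely.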

Compound 4, half-maximal inhibitory concentration: > 10000 nM
Compound 4: no number, only a limit; the forecaster's own chance of this, stated with the estimate: 70%; the middle value lies on the limit itself.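

In this assay, compound 2 and compound 4 each give only a limit, so the step between them, trifluoromethoxy in place of trifluoromethyl, cannot be read: the limit of > 10000 nM in this assay, at which 4 of the 4 values shown sit.

The compounds shown leave open whether any compound in this series has a measurable half-maximal inhibitory concentration in this assay.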